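The compounds below may be only part of what the source reports. "The series", "measured", "known", "first", "only" and "open" are said of these compounds alone.

Measured compounds:
Compound 1, `C/C=C1/[C@H](O[C@@H]2O[C@H](COC(C)=O)[C@@H](OC(C)=O)[C@H](OC(C)=O)[C@H]2OC(C)=O)OC=C(C(=O)O)[C@H]1CC(=O)O`: > 20000 nM
Compound 2, `C/C=C1/[C@H](O[C@@H]2O[C@H](CO)[C@@H](O)[C@H](O)[C@H]2O)OC=C(C(=O)OC)[C@H]1CC(=O)OCC`: > 15000 nM
Compound 3, `C/C=C1/[C@H](O[C@@H]2O[C@H](CO)[C@@H](O)[C@H](O)[C@H]2O)OC=C(C(=O)OC)[C@H]1CC(=O)NCCC`: > 20000 nM

Compound 2 is the starting point. In a functional assay on SK-BR-3 cells (Homo sapiens) for antiproliferative activity, read by MTT assay, with a stated time of 72 h (on this read-out higher numbers stand for weaker inhibition and lower numbers for stronger inhibition), compound 2 gives only a limit, > 15000 nM. Compound 1 likewise gives only a limit in this assay. Compound 3 also gives only a limit in this assay. None of the three therefore stands at a number; compound 2 is neither stronger nor weaker than the others on what is shown, since the three values are limits the limit of > 15000 nM in this assay, at which 1 of the 3 values shown sits, and (the limit of > 20000 nM in this assay, at which 2 of the 3 values shown sit).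

Within the data shown here, the one step between measured compounds, a step that the two limits leave unreadable from compound 2 to compound 3, cannot be read, because both ends sit at limits. It thus gives no measure of how much a change at the carbonyl carbon on the side chain can move the read-out.

The step from compound 2 to compound 4, `C/C=C1/[C@H](O[C@@H]2O[C@H](CO)[C@@H](O)[C@H](O)[C@H]2O)OC=C(C(=O)OC)[C@H]1CC(=O)OCCCc1ccc(OC)c(OC)c1`, is 3,4-dimethoxybenzyl in place of hydrogen on a saturated chain carbon, two bonds along the chain from an oxygen next to a carbonyl group. No measured step bears directly on it; the shown values say only that compounds of this core with small groups on that chain have not reached a number in this assay. The expected step is an at least 1.2-fold lower number from compound 2 to compound 4 (0.09 log units; that floor lies within the scatter), in the direction of stronger inhibition but without a measured precedent. Compound 4 is therefore estimated at 12000 nM, with a range from 3000 nM to 40000 nM, and a fair chance that this assay again reports only a limit.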

Compound 4, half-maximal inhibitory concentration: > 20000 nM
Compound 4: no number, only a limit (the forecaster's own chance of this, stated with the estimate: 55%); at least 1.6-fold (0.22 log units) between middle value and limit.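

In this assay compound 4 gives > 20000 nM and this is a limit, not a number. Compound 2 also stands at a limit, and the step between compound 2 and compound 4 cannot be read. The compounds shown leave open whether any change on the side chain of the shared core reaches a number in this assay at all.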